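A few compounds are considered here, and "the series" means these few. Any claim that something is new, unique, unknown or untested is made for them only; others in the source may bear on it.

Going by the values given here, in a functional assay on Hep 3B2 cells (Homo sapiens) for inhibition (a higher number here means a weaker inhibitor, a lower number a stronger inhibitor), compound 1 `CCn1c(SCC(=O)Nc2ccc(C(=O)O)cc2)nnc1-c1ccncc1` gives 17900 nM, the highest of the three numbers so far. Compound 3 `CONC(=O)c1ccccc1Nc1nc(Nc2cc(C)nn2C(C)C)ncc1Cl` gives 6910 nM, but it is built on a different core, so it offers no direct comparison. Compound 2 `C=CCn1c(SCC(=O)Nc2ccc(C(=O)O)cc2)nnc1-c1ccncc1` gives 2880 nM. Compound 4 `O=C(CSc1nnc(-c2ccncc2)n1-c1ccccc1)Nc1ccc(C(=O)O)cc1` remains unmeasured, and its change is phenyl in place of ethyl on an aromatic nitrogen. Among the compounds with values here, the only measured step that bears on this is a 6.2-fold lower number from compound 1 to compound 2 (0.79 log units; beyond the scatter), a modest step from vinyl in place of methyl in that same side chain. One step is thin support, so a somewhat smaller move in the same direction is expected, namely a 3.0-fold lower number from compound 1 to compound 4 (0.47 log units; beyond the scatter). For compound 4 the estimated value is 6000 nM, with an expected range of 1500 nM to 20000 nM.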

Compound 4, half-maximal inhibitory concentration: 4830 nM
Estimate against measurement, compound 4: 1.2-fold (0.09 log units) above, and the stated range covers the measured number.
By their numbers in this assay, from the lowest: compounds 2, 4 and 3 (each within the scatter of the next, the first and the last beyond it); then compound 1.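

In this assay, this aromatic nitrogen accepts a six-membered aromatic ring as well as a short chain: phenyl in place of ethyl gives a 3.7-fold lower number from compound 1 to compound 4 (0.57 log units; beyond the scatter) on the shared core. Phenyl in place of allyl gives a 1.7-fold higher number from compound 2 to compound 4 (0.22 log units; within the scatter) and so does not set these two groups apart. Nothing available explains either step.

As far as these compounds go, whether an aromatic ring is needed on this nitrogen remains open, since a cyclohexyl ring or a longer chain such as butyl could serve equally well. The effect of a benzyl group, which sets the phenyl ring one carbon further out, is also unknown.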